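A few compounds are considered here, and "the series" means these few. Any claim that something is new, unique, unknown or untested is made for them only; others in the source may bear on it.

Measured so far in a functional assay, read by fluorescence and spectrophotometry, with a stated time of 1 h (on this read-out lower numbers stand for an effect already at smaller amounts and higher numbers for an effect only at larger amounts of compound), and still open:
- compound 1 `CCCCCCCCCCCCS(=O)(=O)/C=C/c1ccc(O)c(O)c1` gives 8500 nM
- compound 2 `O=S(=O)(/C=C/c1ccc(O)c(O)c1)CCCCCCCO` gives 5900 nM
- compound 3 `CCCCCCCCCCCS(=O)(=O)/C=C/c1ccc(O)c(O)c1` has no value yet

Going by the values given here, compound 2 stands level with compound 1, the only other measured compound. Among the compounds with values here, the single measured step is a 1.4-fold lower number from compound 1 to compound 2 (0.16 log units; within the scatter) and it put hydroxy in place of pentyl at the place now in question. The structural change ahead is butyl in place of hydroxy on a saturated chain carbon, seven bonds along the chain from a sulfonyl sulfur and it puts butyl in place of hydroxy on that same saturated chain carbon, seven bonds along the chain from a sulfonyl sulfur. That one step runs the opposite way and is small, so no step beyond the scatter is expected in this assay, in either direction. The estimated step is a 1.3-fold higher number from compound 2 to compound 3 (0.10 log units; within the scatter) and the direction is only tentative. The estimated value for compound 3 is 7500 nM (3500 nM to 16000 nM).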

Compound 3, half-maximal effective concentration: 11400 nM
For compound 3 the middle estimate is 1.5-fold (0.18 log units) below the measured one; the range from low to high includes it.
By their numbers in this assay, from the lowest: compounds 2, 1 and 3 (each within the scatter of the next).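

Butyl in place of hydroxy on a saturated chain carbon, seven bonds along the chain from a sulfonyl sulfur, gives a 1.9-fold higher number from compound 2 to compound 3 (0.29 log units; within the scatter) in this assay, so even this swap of a hydroxy for a carbon chain stays inside the noise. Hydrogen in place of methyl on a saturated chain carbon gives a 1.3-fold higher number from compound 1 to compound 3 (0.13 log units; within the scatter), which is just as small. Nothing measured here explains these results. Going by these compounds, an amine or a carboxylic acid at this place remains open, as does a much longer chain, so it is unknown whether any change here can move the number beyond the scatter.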